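From Methyl to Trifluoromethyl on an Aromatic Carbon

This account rests on a few compounds, and the source may have more. Where it says the series, first, only, none or still open, it means among the compounds named here.

In a functional assay on KB cells (Homo sapiens) for antiproliferative activity, read by sulforhodamine B assay, with a stated time of 3 days (on this read-out lower numbers stand for an effect already at smaller amounts and higher numbers for an effect only at larger amounts of compound), compound 1 (`CCC1=C(O)c2c(oc(-c3ccccc3)cc2=O)C(CC)(CC)C1=O`) gives > 236 uM, which is a limit of the assay and not a number. Among the compounds with values here, compound 2 (`CCC1=C(O)c2c(oc(-c3cccc(C)c3)cc2=O)C(CC)(CC)C1=O`) gives 49.7 uM, the only number so far. Methyl in place of hydrogen on an aromatic carbon produced an at least 4.7-fold lower number from compound 1 to compound 2 (0.67 log units; beyond the scatter), a step that rests on (the limit of > 236 uM in this assay, at which 1 of the 2 values shown sits). Compound 3 (`CCC1=C(O)c2c(oc(-c3cccc(C(F)(F)F)c3)cc2=O)C(CC)(CC)C1=O`) has trifluoromethyl in place of methyl on an aromatic carbon. That single step, from hydrogen to methyl, offers only a weak guide to exchanging one group for another, so the expected result is a 1.2-fold lower number from compound 2 to compound 3 (0.07 log units; within the scatter), with no change beyond the scatter. Compound 3 is estimated at 42 uM, within an expected range of 15 uM to 120 uM.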

Compound 3, concentration for half-maximal effect: 35.7 uM
Compound 3: the middle estimate sits 1.2-fold (0.07 log units) above what was measured; low and high end bracket the measured number.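

At this position, trifluoromethyl in place of methyl gave a 1.4-fold lower number from compound 2 to compound 3 (0.14 log units; within the scatter), so in this assay the two groups cannot be told apart. Trifluoromethyl in place of hydrogen gave an at least 6.6-fold lower number from compound 1 to compound 3 (0.82 log units; beyond the scatter), so a second group on this aromatic carbon also departs from the hydrogen of compound 1 by more than the scatter. The true size of that step stays unknown, as it rests on a limit: the limit of > 236 uM in this assay, at which 1 of the 3 values shown sits.

On these data alone, whether an amine, a carboxylic acid or a longer chain on this carbon would give a number like those of compound 2 and compound 3 remains open.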